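Swapping a sulfated tail for a cycloheptyl ring

This account rests on a few compounds, and the source may have more. Where it says the series, first, only, none or still open, it means among the compounds named here.

Two compounds share a sulfated sugar core carrying an acetylated amino-acetamide arm, and differ only in the group on the amide-type nitrogen of that arm. Compound 1 `CO[C@H]1O[C@H](CNC(=O)CN(Cc2ccccc2)C(C)=O)[C@@H](OS(=O)(=O)O)[C@H](OS(=O)(=O)O)[C@@H]1OS(=O)(=O)O` carries a benzyl group there; in an assay on isolated protein for binding affinity to vascular endothelial growth factor A, long form (Homo sapiens), read by surface plasmon resonance (on this read-out lower numbers stand for tighter binding and higher numbers for weaker binding), compound 1 gives 77000 nM. Compound 2 `CO[C@H]1O[C@H](CNC(=O)CN(CCOS(=O)(=O)O)C(C)=O)[C@@H](OS(=O)(=O)O)[C@H](OS(=O)(=O)O)[C@@H]1OS(=O)(=O)O` carries a 2-(sulfooxy)ethyl group instead, and in this assay compound 2 gives 280000 nM, the higher and thus weaker of the two numbers. Among the measured compounds shown here, the one measured step, a 3.6-fold higher number from compound 1 to compound 2 (0.56 log units; beyond the scatter), shows that replacing the phenyl-bearing group with the sulfated chain weakened binding modestly.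

Compound 3 `CO[C@H]1O[C@H](CNC(=O)CN(C(C)=O)C2CCCCCC2)[C@@H](OS(=O)(=O)O)[C@H](OS(=O)(=O)O)[C@@H]1OS(=O)(=O)O` takes the opposite direction: cycloheptyl in place of 2-(sulfooxy)ethyl on an amide-type nitrogen. For the measured compounds named here, the sulfated chain leaves and a plain carbon ring enters, which resembles the reverse of the only measured step. Because a 3.6-fold higher number from compound 1 to compound 2 (0.56 log units; beyond the scatter) was modest, a modest return toward tighter binding is expected, a 4.0-fold lower number from compound 2 to compound 3 (0.60 log units; beyond the scatter). Compound 3 is therefore expected to give about 70000 nM in this assay, with a plausible range from 25000 nM to 200000 nM.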

Compound 3, dissociation constant: 3000000 nM
Estimate against measurement, compound 3: 43-fold (1.63 log units) below, and the stated range ends below it.
By their numbers in this assay, from the lowest: compound 1; then compound 2; then compound 3.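

In this assay, cycloheptyl on the amide-type nitrogen gives an 11-fold higher number from compound 2 to compound 3 (1.03 log units; beyond the scatter), and measured against the benzyl group the change is larger still, a 39-fold higher number from compound 1 to compound 3 (1.59 log units; beyond the scatter). Removing the sulfated chain therefore does not by itself tighten binding, and the result depends on what takes its place: benzyl and cycloheptyl both lack a sulfate, yet compound 1 and compound 3 stand at opposite ends of the order, with compound 2 in the middle. The group on this nitrogen thus spans a much wider range of numbers than the first pair alone showed, and nothing available here accounts for why the cycloheptyl ring fares worst.

The compounds shown leave open whether a cyclohexylmethyl group or a phenyl ring set directly on the nitrogen would fall nearer compound 1 or compound 3, which would help separate the effect of the ring type from that of the carbon linking it to the nitrogen. Also open, going by these compounds, is how a plain ethyl chain would compare with the 2-(sulfooxy)ethyl group of compound 2, a comparison that would isolate the contribution of the sulfate from that of the chain carrying it.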